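From 4-cyanophenyl to 4-chlorophenyl: a working estimate

The compounds below may be only part of what the source reports. "The series", "measured", "known", "first", "only" and "open" are said of these compounds alone.

Of the compounds shown here, three have been measured in a functional assay on HL-60 cells (Homo sapiens) for antiproliferative activity, read by sulforhodamine B assay, with a stated time of 72 h; a lower number here means a stronger inhibitor, a higher number a weaker inhibitor. Compound 1 `FC(F)(F)c1ccccc1NC(=S)N/N=C/c1ccc2ccccc2n1` gives 13200 nM, compound 2 `CN(C)C(=S)N/N=C/c1ccc2cccnc2n1` gives 560 nM, and compound 3 `N#Cc1ccc(NC(=S)N/N=C/c2ccc3ccccc3n2)cc1` gives 4660 nM. Compound 3 therefore holds the second-highest number of the three, with gaps beyond the scatter to both neighbours. Among the measured compounds shown here, these compounds differ in more than one place, so no single-change step has been measured.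

Compound 4 `S=C(N/N=C/c1ccc2ccccc2n1)Nc1ccc(Cl)cc1` has chloro in place of cyano on an aromatic carbon, para to a large group, the change from 4-cyanophenyl to 4-chlorophenyl: chloro in place of cyano on an aromatic carbon. The data contain no direct measurement of this exchange, so no step beyond the scatter is expected in this assay, and no direction can be firmly assigned. The expected outcome is a 1.2-fold lower number from compound 3 to compound 4 (0.07 log units; within the scatter), an estimate that stays within the scatter. The range is kept wide enough to approach compound 1 at 13200 nM. For compound 4 the estimated value is 4000 nM, with an expected range of 1300 nM to 12000 nM.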

Compound 4, half-maximal inhibitory concentration: > 100000 nM
Compound 4: only a limit was reported; the forecaster's own chance of this, stated with the estimate: 5%; middle value at least 25-fold (1.39 log units) from the limit.
By their numbers in this assay, from the lowest: compound 2; then compound 3; then compound 1. At a limit, above all of these: compound 4.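

In this assay, the exchange of 4-cyanophenyl for 4-chlorophenyl is the only single-place change among the compounds shown, and it gives an at least 21-fold higher number from compound 3 to compound 4 (1.33 log units; beyond the scatter). The value of compound 4 is a limit of the assay and not a number, so this step sets only a minimum size: the limit of > 100000 nM in this assay, at which 1 of the 4 values shown sits. The position on the aromatic carbon, para to a large group, is therefore not indifferent to its substituent, as chloro in place of cyano alone moves the read-out beyond the scatter.

Going by these compounds, the true size of the step remains open, as does whether it follows from the presence of cyano or of chloro. An amine or a methoxy group at the same position would show whether compound 3 or compound 4 is the exception in this series.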